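From 4-chlorophenyl to methyl in compound 4

A few compounds are considered here, and "the series" means these few. Any claim that something is new, unique, unknown or untested is made for them only; others in the source may bear on it.

Compound 1 `COc1ccc(-n2nc(C(=O)N3CCCCC3)cc2-c2ccc(Cl)cc2)nn1` gives 41 nM
Compound 2 `COc1ccc(-n2nc(C(=O)Nc3ccncc3)cc2-c2ccc(Cl)cc2)nn1` gives 110 nM
Compound 3 `COc1ccc(NC(=O)c2cc(-c3ccc(Cl)cc3)n(-c3ccc(OC)nn3)n2)cc1` gives 400 nM

In a functional assay on a cell-free system (Platelet, plasma, Homo sapiens) for inhibition, read by turbidimetry, with a stated time of 3 min (on this read-out lower numbers stand for stronger inhibition and higher numbers for weaker inhibition), compound 1 holds the lowest number of the three. The other two lie beyond the scatter from it, with a 2.7-fold higher number from compound 1 to compound 2 (0.43 log units; beyond the scatter) and a 9.8-fold higher number from compound 1 to compound 3 (0.99 log units; beyond the scatter), while a 3.6-fold higher number from compound 2 to compound 3 (0.56 log units; beyond the scatter) separates the remaining pair.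

Compound 4 `COc1ccc(-n2nc(C(=O)N3CCCCC3)cc2C)nn1` has not yet been measured. It keeps the (piperidin-1-yl)carbonyl group of compound 1 and carries methyl in place of 4-chlorophenyl on an aromatic carbon.

Among the measured compounds shown here, no measured step touches this place, since all three change only the group on the carbonyl carbon, and no measured compound lacks the 4-chlorophenyl. They bear on it only as a yardstick. The largest, a 9.8-fold higher number from compound 1 to compound 3 (0.99 log units; beyond the scatter), came from a single substitution that left the 4-chlorophenyl in place, and the new change removes a whole aromatic ring, so a larger step toward a higher number is expected, of poorly fixed size.

The expected step in this assay is a 61-fold higher number from compound 1 to compound 4 (1.79 log units; beyond the scatter) as estimated here. For compound 4 the estimated value is 2500 nM, with an expected range from 300 nM to 20000 nM.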

Compound 4, half-maximal inhibitory concentration: > 10000 nM
Compound 4: a limit, no number; the forecaster's own chance of this, stated with the estimate: 25%; at least 4.0-fold (0.60 log units) between middle value and limit.
By their numbers in this assay, from the lowest: compound 1; then compound 2; then compound 3. At a limit, above all of these: compound 4.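

At this position, next to the ring atom that bears a 6-methoxypyridazin-3-yl group, the 4-chlorophenyl counts for far more than the group on the carbonyl carbon: methyl in its place gives an at least 240-fold higher number from compound 1 to compound 4 (2.38 log units; beyond the scatter) in this assay, against a 9.8-fold higher number from compound 1 to compound 3 (0.99 log units; beyond the scatter) for the largest change shown at the carbonyl carbon. Methyl therefore does not stand in for the 4-chlorophenyl, even with the (piperidin-1-yl)carbonyl group kept. As far as these compounds go, the value of compound 4, > 10000 nM, is a limit of the assay and not a number, so the full size of the step stays unknown: the limit of > 10000 nM in this assay, at which 1 of the 4 values shown sits.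

From the compounds shown here alone, what remains open is whether the aromatic ring or its chlorine carries the effect, a question a plain phenyl at this position would address. A cyclohexyl or a longer chain such as n-butyl could show whether a non-aromatic group restores any inhibition.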